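The compounds below may be only part of what the source reports. "The series", "measured", "known", "first", "only" and "open" are said of these compounds alone.

In a functional assay on PC-3 cells (Homo sapiens) for inhibition, read by sulforhodamine B assay, with a stated time of 48 h, tested at 50 uM (a lower number here means less inhibition of growth, a higher number more inhibition of growth at the concentration tested), compound 1 `COc1ccc([C@@H]2C/C(=N/OCc3cn(-c4ccc(C(=O)c5ccccc5)cc4)nn3)c3cc(CC=C(C)C)c(OC)cc3O2)cc1` gives 40% and compound 2 `COc1ccc([C@@H]2C/C(=N/OCc3cn(-c4ccc(C#N)cc4)nn3)c3cc(CC=C(C)C)c(OC)cc3O2)cc1` gives 50%. Compound 3 `COc1ccc([C@@H]2C/C(=N/OCc3cn(-c4ccc(C(N)=O)cc4)nn3)c3cc(CC=C(C)C)c(OC)cc3O2)cc1` gives 100%, the highest of the three numbers. Compound 4 `COc1ccc([C@@H]2C/C(=N/OCc3cn(-c4ccc(NC(C)=O)cc4)nn3)c3cc(CC=C(C)C)c(OC)cc3O2)cc1` keeps the shared core and changes one group: acetamido in place of carbamoyl on an aromatic carbon. Here acetamido stands in place of carbamoyl on an aromatic carbon, para to a large group.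

The measured steps all concern this same place. Replacing cyano with carbamoyl gives a number 50 percentage points higher from compound 2 to compound 3 (beyond the scatter), and replacing the phenyl of benzoyl with amino gives a number 60 percentage points higher from compound 1 to compound 3 (beyond the scatter). Replacing benzoyl with cyano gives only a number 10 percentage points higher from compound 1 to compound 2 (within the scatter). Among the compounds with values here, the group at this place can therefore matter greatly, but no measured step tests acetamido itself. Acetamido resembles carbamoyl in holding a carbonyl and a nitrogen, so a fall as large as the two big steps seems unlikely, though compound 3 at 100% leaves room only for a fall. A moderate downward move is expected, namely a number 30 percentage points lower from compound 3 to compound 4 (beyond the scatter). For compound 4 the estimated value is 70%, within an expected range of 40% to 100%.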

Compound 4, percent growth inhibition at one concentration: 2%
For compound 4 the middle estimate is 68 percentage points above the measured one; the whole stated range lies above it.
By their numbers in this assay, from the lowest: compound 4; then compounds 1 and 2 (each within the scatter of the next); then compound 3.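

In this assay, acetamido in place of carbamoyl gives a number 98 percentage points lower from compound 3 to compound 4 (beyond the scatter), so holding a carbonyl and a nitrogen is not enough to keep the high number of compound 3. Acetamido also compares poorly with the other two groups, giving a number 48 percentage points lower from compound 2 to compound 4 (beyond the scatter) and a number 38 percentage points lower from compound 1 to compound 4 (beyond the scatter), which puts compound 4 lowest of the four. The earlier steps shown here showed only that this place could raise the number; now a swap between two similar-looking groups, in which the ring carbon gains a nitrogen attachment instead of a carbonyl one, is seen to take it from the top to the bottom of the set.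

Nothing available explains why these two groups differ so sharply. As far as these compounds go, how a plain amine or a carboxylic acid at this place would compare with carbamoyl and acetamido remains open.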